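Ring Size and Nitrogen Substituent in Nitrobenzothiazole Amides

The source may hold more compounds than are shown below. What is called first, only, known or untested is meant among the compounds shown, and "the series" means these compounds.

Measured so far:
Compound 1, `O=C(CN1CCNCC1)Nc1nc2cc([N+](=O)[O-])ccc2s1`: 12.3%
Compound 2, `O=C(CN1CCN(c2ccccc2)CC1)Nc1nc2cc([N+](=O)[O-])ccc2s1`: 34.8%
Compound 3, `O=C(CN1CCCNCC1)Nc1nc2cc([N+](=O)[O-])ccc2s1`: 17.4%

All three compounds share a common core and were tested in a functional assay on the whole organism (strain Wistar) for inhibition, with Rattus norvegicus as the target, read by paw edema, with a stated time of 2 h, at a dose of 30 mg/kg; a higher number here means more inhibition at the dose given (going by the name of the read-out), a lower number less inhibition. Compound 3 sits second highest of the three numbers; its gap to compound 1 is within the scatter, while compound 2 stands beyond the scatter above it.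

Compound 4, `CCN1CCN(CC(=O)Nc2nc3cc([N+](=O)[O-])ccc3s2)CC1`, has not been measured. Its change from compound 3 is 4-ethylpiperazin-1-yl in place of 1,4-diazepan-1-yl on a saturated chain carbon bound to a carbonyl carbon. Going by the values given here, two measured steps bear on this. The step of a number 5.1 percentage points higher from compound 1 to compound 3 (within the scatter) shows that swapping the ring size alone moved little. The step of a number 22.5 percentage points higher from compound 1 to compound 2 (beyond the scatter) shows that placing a substituent on the amine nitrogen in the ring raised inhibition modestly. Compound 4 combines a return to the six-membered ring with an ethyl group on that nitrogen, so a modest rise is expected, though an ethyl is a smaller change than a phenyl.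

For compound 4 an upward step of a number 6.6 percentage points higher from compound 3 to compound 4 (within the scatter) is estimated, giving an expected value of 24%, with a range from 10% to 40%.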

Compound 4, a percentage reported as inhibition, in the whole organism at one dose (the size of the read-out at that dose, not a potency): 17.4%
Estimate against measurement, compound 4: 6.6 percentage points above; low and high end bracket the measured number.
By their numbers in this assay, from the lowest: compounds 1, 3 and 4 (each within the scatter of the next); then compound 2.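

In this assay, not every substituent on the ring nitrogen behaves like phenyl: ethyl in place of hydrogen gives a number 5.1 percentage points higher from compound 1 to compound 4 (within the scatter) and ethyl in place of phenyl gives a number 17.4 percentage points lower from compound 2 to compound 4 (beyond the scatter) at this position, so among the compounds shown only phenyl stands apart. The swap of 1,4-diazepan-1-yl for 4-ethylpiperazin-1-yl, which changes the ring size and adds the ethyl in one move, gives no change at the digits printed from compound 3 to compound 4 (within the scatter) and so does not tell the two changes apart. No measurement at hand accounts for the difference between phenyl and ethyl.

As far as these compounds go, it remains open whether a benzyl group or a longer chain such as butyl on that nitrogen would fall nearer to phenyl or to ethyl. From the compounds shown here alone, it is also open whether phenyl on the seven-membered ring would behave as it does on the six-membered one.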